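This account rests on a few compounds, and the source may have more. Where it says the series, first, only, none or still open, it means among the compounds named here.

Cytotoxicity in this set is measured in a functional assay on A549 cells (Homo sapiens) for cytotoxicity, read by colorimetric assay and MTT assay, with a stated time of 3 days, tested at 1 uM; a lower number here means a stronger effect, a higher number a weaker effect of the compound at the concentration tested. Compound 1 `O=C1COc2ccc(-c3[nH]c(-c4ccc(C(F)(F)F)cc4)nc3-c3ccccc3)cc2N1` gives 103% there, the top of the three numbers shown: compound 2 `O=C1COc2ccc(-c3nn(-c4ccc(Cl)cc4)cc3-c3ccccc3)cc2N1` with 84.4% lies beyond the scatter from it, whereas compound 3 `COc1ccc(-n2cc(-c3ccccc3)c(-c3ccc4c(c3)NC(=O)CO4)n2)cc1` with 95.6% lies within the scatter of compound 1. Within the data shown here, the one step that can be read from compounds differing in a single place, a number 11.2 percentage points higher from compound 2 to compound 3 (beyond the scatter), concerns the substituent on the pendant aryl ring of a different core and is modest.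

Compound 4 `O=C1COc2ccc(-c3[nH]c(-c4ccccc4)nc3-c3ccccc3)cc2N1` is not yet measured. It differs from compound 1 by hydrogen in place of trifluoromethyl on an aromatic carbon. Among the measured compounds shown here, no measured pair shows this exact exchange; the step from compound 2 to compound 3 is the nearest relative, a change of the group on the same type of aryl position, and it moved the number only modestly. Compound 1 already sits at a value meaning essentially no effect at the tested concentration, so compound 4 is expected at 100%, between 85% and 112%. The expected step is a number 3 percentage points lower from compound 1 to compound 4 (within the scatter), that is none beyond the scatter.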

Compound 4, a percentage reported as activity, at one concentration (the size of the read-out at that concentration, not a potency): 95.6%
Compound 4: middle estimate off by 4.4 percentage points, on the high side; measured number inside the range.
By their numbers in this assay, from the lowest: compound 2; then compounds 3, 4 and 1 (each within the scatter of the next).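

In this assay, the exchange on the aromatic carbon para to a large group, 4-(trifluoromethyl)phenyl to phenyl, gives a number 7.4 percentage points lower from compound 1 to compound 4 (within the scatter), so at this position the read-out does not separate trifluoromethyl from hydrogen. Among these compounds, this is the first single-place reading on the core of compound 1; the only earlier one, a number 11.2 percentage points higher from compound 2 to compound 3 (beyond the scatter), belongs to a different core and a different exchange, and it cannot be carried over to this one. No measurement shown bears on the reason for this outcome.

Open, going by these compounds, is whether an amine or a carboxylic acid at this position would give a number beyond the scatter from that of compound 1. Also open, on these data alone, is whether the two compounds would differ at other concentrations, since a reading at a single concentration gives no potency.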